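This account rests on a few compounds, and the source may have more. Where it says the series, first, only, none or still open, it means among the compounds named here.

Measured in a functional assay on Jurkat cells (Homo sapiens) (a higher number here means a weaker inhibitor, a lower number a stronger inhibitor), each value below being a limit of the assay and not a number:

- compound 1 `CC(C)[C@H](NC(=O)COc1cccc2ccccc12)C(=O)N[C@@H](CC(=O)O)C(=O)COc1ccc2ccccc2c1`: > 100000 nM
- compound 2 `CC(C)[C@H](NC(=O)COc1cccc2ccccc12)C(=O)N[C@@H](CC(=O)O)C(=O)COc1ccc(C(F)(F)F)cc1`: > 100000 nM
- compound 3 `CC(C)[C@H](NC(=O)COc1cccc2ccccc12)C(=O)N[C@@H](CC(=O)O)C(=O)COc1ccccc1[N+](=O)[O-]`: > 100000 nM

Compound 3 stands at > 100000 nM, which is a limit. It has company there: the limit of > 100000 nM in this assay, at which 3 of the 3 values shown sit.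

Compound 4 `CC(C)[C@H](NC(=O)COc1cccc2ccccc12)C(=O)N[C@@H](CC(=O)O)C(=O)COc1ccc(F)cc1F` keeps the rest of compound 3 and changes one group, 2,4-difluorophenyl in place of 2-nitrophenyl on an oxygen on a saturated carbon.

Three measured steps swap a group at this same place. There is a step that the two limits leave unreadable from compound 1 to compound 3, there is a step that the two limits leave unreadable from compound 2 to compound 3, and there is a step that the two limits leave unreadable from compound 1 to compound 2. None of them gives a size, so they offer no measured size or direction to carry over. With all three compounds at the limit, the likeliest result in this assay is that compound 4 is reported at the limit too, although a readable number remains possible.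

The expected step is a number no higher from compound 3 to compound 4 (the limit leaves the size open), an estimate with no firm direction. Compound 4 is expected at 100000 nM, within an estimated range of 10000 nM to 200000 nM.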

Compound 4, half-maximal inhibitory concentration: 33200 nM
Beside the measured number, compound 4's estimate is 3.0-fold (0.48 log units) above it, and the stated range covers the measured number.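

In this assay, going by these compounds alone, the group on this oxygen can bring a compound off the limit, something the earlier compounds could not show, as the steps among them cannot be read. The change to 2,4-difluorophenyl gives an at least 3.0-fold lower number from compound 3 to compound 4 (0.47 log units; beyond the scatter), then an at least 3.0-fold lower number from compound 2 to compound 4 (0.47 log units; beyond the scatter), and also an at least 3.0-fold lower number from compound 1 to compound 4 (0.47 log units; beyond the scatter); each of these sizes is only a floor, set by a limit on one side. Of the four groups shown at this position, only 2,4-difluorophenyl gives a readable number, while naphthalen-2-yl, 4-(trifluoromethyl)phenyl and 2-nitrophenyl stay at a limit: the limit of > 100000 nM in this assay, at which 3 of the 4 values shown sit.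

Whether both fluorines are needed stays open, since a plain phenyl or a 4-fluorophenyl group on this oxygen is not among the compounds shown. Also open, from the compounds shown here alone, is whether any other group here, such as a pyridine ring, would lower the number further.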